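The source may report more compounds than this note shows. Statements on the series, on what has been measured and on what is new or still open speak of the compounds shown alone.

In a functional assay on COLO 205 cells (Homo sapiens) for inhibition, read by MTT assay, with a stated time of 24 h (on this read-out lower numbers stand for stronger inhibition and higher numbers for weaker inhibition), compound 1 `[O-]/[N+](=C\c1cn(-c2ccc(Cl)cc2)nn1)c1ccccc1` gives 9700 nM. Compound 2 `CCCCCCCCn1cc(/C=[N+](\[O-])Cc2ccccc2)nn1` reaches only a limit of the assay in this assay, > 100000 nM. Compound 3 `CCCCCCCCCCn1cc(/C=[N+](\[O-])Cc2ccccc2)nn1` likewise shows only a limit in this assay, > 100000 nM. Between them lies a step that the two limits leave unreadable from compound 2 to compound 3, and the limit of > 100000 nM in this assay, at which 2 of the 3 values shown sit, marks where both stand. For the measured compounds named here, compound 2 thus stands at a limit rather than a number, and the one bounded value shown, that of compound 1, belongs to a differently built molecule. Compound 4 `CCCCCCCCn1cc(/C=[N+](\[O-])C(C)(C)C)nn1` differs from compound 2 by tert-butyl in place of benzyl on a double-bonded nitrogen. Going by the values given here, no measured step touches this part of the molecule: the only measured step, from compound 2 to compound 3, alters the chain on the aromatic nitrogen, and because of the limit of > 100000 nM in this assay, at which 2 of the 3 values shown sit, its size cannot be read. Among the compounds with values here, no measured step therefore bears on the change to compound 4, and no direction beyond the scatter can be expected from the data. Compound 4 is estimated at 150000 nM, with a range from 30000 nM to 500000 nM, most likely again reported as a limit. This estimate amounts to an expected step that the limit leaves unreadable from compound 2 to compound 4.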

Compound 4, half-maximal inhibitory concentration: 30800 nM
The estimate for compound 4 lay 4.9-fold (0.69 log units) above the measured number, within the range that was stated.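

For the compounds shown here, the group on the double-bonded nitrogen is the first place where a change can be read in this assay: tert-butyl in place of benzyl gives an at least 3.2-fold lower number from compound 2 to compound 4 (0.51 log units; beyond the scatter). Compound 4, at 30800 nM, therefore shows that this position affects the read-out, which the unreadable step in the chain on the aromatic nitrogen could not show for that part of the molecule. The step is given only as a lower bound because compound 2 stands at a limit: the limit of > 100000 nM in this assay, at which 2 of the 4 values shown sit.

As far as these compounds go, whether the gain goes with the loss of the six-membered aromatic ring or with the tert-butyl group itself remains open, and a cyclohexyl or isopropyl group at this position would bear on that question. The compounds shown also leave open whether the same change would hold with a shorter chain on the aromatic nitrogen.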